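Larger cycloalkyl groups on the amino nitrogen

A few compounds are considered here, and "the series" means these few. Any claim that something is new, unique, unknown or untested is made for them only; others in the source may bear on it.

Measured in a functional assay on CHO cells for antagonist activity at adenosine receptor A2b (Homo sapiens); on this read-out higher numbers stand for weaker inhibition and lower numbers for stronger inhibition:
compound 1, `COc1ccc(CNc2ncc(C(=O)O)c3nc(-c4ccco4)nn23)cc1OC`: > 30000 nM, which is a limit of the assay
compound 2, `CCOC(=O)c1cnc(NC2CC2)n2nc(-c3ccco3)nc12`: 2260 nM
compound 3, `CCOC(=O)c1cnc(NC2CCCC2)n2nc(-c3ccco3)nc12`: 4620 nM

For the measured compounds named here, compound 3 holds the higher of the two numbers, and the one measured step, a 2.0-fold higher number from compound 2 to compound 3 (0.31 log units; beyond the scatter), came with cyclopentyl replacing cyclopropyl on the amino nitrogen. Compound 4, `CCOC(=O)c1cnc(NCC2CCCCC2)n2nc(-c3ccco3)nc12`, carries the change (cyclohexylmethyl in place of cyclopentyl on a nitrogen on an aromatic ring). Going by the values given here, only that step bears on it; it was modest, and a further enlargement of the group on the same nitrogen is therefore expected to give a step of similar size in the same direction in this assay, a weakening that may still brush the scatter. Compound 4 is accordingly estimated at 7500 nM, with a range from 2500 nM to 22000 nM. That estimate means a step of a 1.6-fold higher number from compound 3 to compound 4 (0.21 log units; within the scatter).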

Compound 4, inhibition constant: > 10000 nM
Compound 4 ended at the assay's limit; the forecaster's own chance of this, stated with the estimate: 15%; middle value at least 1.3-fold (0.12 log units) away from the limit.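

In this assay, the change to cyclohexylmethyl brought an at least 2.1-fold higher number from compound 3 to compound 4 (0.33 log units; beyond the scatter), so the weakening seen with cyclopentyl continues on this nitrogen and clears the scatter. Taken from cyclopropyl, the same position shows an at least 4.4-fold higher number from compound 2 to compound 4 (0.64 log units; beyond the scatter), and compound 2, compound 3 and compound 4 rise in order with no compound among them against it. Compound 4 stands at a limit, so both steps give only a minimum size: the limit of > 10000 nM in this assay, at which 1 of the 4 values shown sits.

Still open, going by these compounds, is whether cyclohexyl directly on the nitrogen would read like cyclohexylmethyl. Also open, on these data alone, is whether a methyl group or a short unbranched chain there would read lower than cyclopropyl.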